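A few compounds are considered here, and "the series" means these few. Any claim that something is new, unique, unknown or untested is made for them only; others in the source may bear on it.

Compound 1 (`O=C(/C=C/c1ccc(Br)cc1)Oc1ccc(/C=C2\CCCCC2=O)cc1`) gives 180000 nM in a functional assay on MOLT-4 cells (Homo sapiens) (a higher number here means a weaker inhibitor, a lower number a stronger inhibitor), and compound 2 (`CN(C)CC1CCC/C(=C\c2ccc(OC(=O)/C=C/c3ccc(Br)cc3)cc2)C1=O`) gives 3060 nM in the same test. Between these two lies the only measured step, a 59-fold lower number from compound 1 to compound 2 (1.77 log units; beyond the scatter) on setting (dimethylamino)methyl in place of hydrogen on a saturated ring carbon, and it is large. Compound 3 (`O=C1CCCC/C1=C\c1ccc(OC(=O)c2ccc(Cl)cc2)cc1`) gives 38000 nM in this assay and so holds the second highest of the three numbers, with compound 1 its nearest neighbour on the higher side and compound 2 further away on the lower side. Compound 4 (`COc1ccc(C(=O)Oc2ccc(/C=C3\CCCCC3=O)cc2)cc1`) differs from compound 3 by methoxy in place of chloro on an aromatic carbon, para to a large group (methoxy in place of chloro on an aromatic carbon). Within the data shown here, no measured step touches that place. Among the measured compounds shown here, the single step available, a 59-fold lower number from compound 1 to compound 2 (1.77 log units; beyond the scatter) between compound 1 and compound 2, concerns a saturated ring carbon and gives no guide to size or direction here, and compound 4 does not carry the (dimethylamino)methyl group. For the measured compounds named here, with no measured precedent, no move beyond the scatter is expected, and the expected change is a 1.1-fold higher number from compound 3 to compound 4 (0.02 log units; within the scatter) in this assay as a best guess. Compound 4 is estimated at 40000 nM in this assay with 14000 nM to 110000 nM as the expected range.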

Compound 4, half-maximal inhibitory concentration: 34000 nM
Beside the measured number, compound 4's estimate is 1.2-fold (0.07 log units) above it, within the range that was stated.
By their numbers in this assay, from the lowest: compound 2; then compounds 4 and 3 (each within the scatter of the next); then compound 1.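

In this assay, methoxy in place of chloro on an aromatic carbon, para to a large group, gives a 1.1-fold lower number from compound 3 to compound 4 (0.05 log units; within the scatter) and so shows that, for this pair, 4-methoxyphenyl and 4-chlorophenyl cannot be told apart at this place. Among these compounds, the change adds one heavy atom and one hydrogen-bond acceptor without moving the number beyond the scatter, whereas the only earlier step, a 59-fold lower number from compound 1 to compound 2 (1.77 log units; beyond the scatter) and large, concerned a saturated ring carbon and said nothing about this aromatic position. No available evidence bears on why these two groups read alike here.

Chloro and methoxy are the only two groups seen at this place, so it remains open whether an amine or a carboxylic acid there would also stay within the scatter. Going by these compounds, it is also open whether (dimethylamino)methyl on the saturated ring carbon would lower the number of compound 3 or compound 4 by a large step, as it does starting from compound 1.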